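Swapping a Methyl for a Nitro Group on an Aniline

This account rests on a few compounds, and the source may have more. Where it says the series, first, only, none or still open, it means among the compounds named here.

Of the compounds shown here, three of one family have been measured in an assay on cell membranes for displacement of a labelled ligand from Neuronal acetylcholine receptor; alpha4/beta2 (Rattus norvegicus); a higher number here means a weaker inhibitor, a lower number a stronger inhibitor. Compound 1 `Cc1ccc(Nc2cncc(N3CC4CC(C3)N4)c2)cc1` gives 0.148 nM and is the strongest binder of the three. Compound 2 `Clc1ccc(Nc2ccc(N3CC4CC(C3)N4)cn2)cc1`, which places the amine-linked aryl group on a differently arranged core, gives 2.49 nM in this assay, a weaker result that lies beyond the usual scatter. Within the data shown here, compound 3 `Clc1cccc(Nc2ccc(N3CC4CC(C3)N4)nn2)c1` gives 1540 nM in this assay, far weaker still; only its two values and those of compound 1 can be compared, and no single-change step links them.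

Compound 4 `O=[N+]([O-])c1ccc(Nc2cncc(N3CC4CC(C3)N4)c2)cc1` is the untested member. It differs from compound 1 in one way: nitro in place of methyl on an aromatic carbon. Everything else, the core and the amine bridge, is kept. Among the measured compounds shown here, because no pair of measured compounds shows this same exchange, the size of the step cannot be read off from the data; it has to be judged.

Compound 4 is estimated to give about 0.4 nM in this assay, within a range of 0.08 nM to 2 nM. This expectation means a small loss from compound 1, a step of a 2.7-fold higher number from compound 1 to compound 4 (0.43 log units; beyond the scatter) that sits close to the edge of the scatter, so compound 4 is expected to remain a very strong binder.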

Compound 4, inhibition constant: 0.0225 nM
For compound 4 the middle estimate is 18-fold (1.25 log units) above the measured one; the whole stated range lies above it.
By their numbers in this assay, from the lowest: compound 4; then compound 1; then compound 2; then compound 3.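

In this assay, exchanging methyl for nitro on an aromatic carbon of the six-membered ring, para to a large group, gives a 6.6-fold lower number from compound 1 to compound 4 (0.82 log units; beyond the scatter). Among these compounds, the earlier compounds offered no single-change step, so this is the first direct reading of what one exchange does in this family: at this position, a group with 3 heavy atoms and 2 hydrogen-bond acceptors replaces one with 1 heavy atom and no acceptors, and the number falls rather than rises. No measurement shown here accounts for that fall, so the step stands as an observation without an explanation.

The compounds shown cannot tell whether this gain is particular to nitro or would also appear with a nitrile, a trifluoromethyl group or an amine on the same carbon, and a single step cannot establish a trend across such groups. From the compounds shown here alone, it also remains open whether the same exchange of methyl for nitro would move the number in the same direction on the differently arranged cores of compound 2 and compound 3.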